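This account rests on a few compounds, and the source may have more. Where it says the series, first, only, none or still open, it means among the compounds named here.

Compound 1 `COc1ccc([C@H]2CC(=O)N(c3cccc(NCC4CCOC4)c3)C2)cc1OC1CCCC1`: in a functional assay on HEK293 cells (Homo sapiens) for cytotoxicity (a lower number here means that less compound is tolerated, a higher number that more compound is tolerated), compound 1 gives only a limit, > 10000 nM.
Compound 2 `COc1ccc([C@H]2CC(=O)N(c3cccc(NS(=O)(=O)c4ccccc4Cl)c3)C2)cc1OC1CCCC1`: in this assay compound 2 gives only a limit, > 10000 nM.
Compound 3 `COc1ccc([C@H]2CC(=O)N(c3cccc(NS(=O)(=O)c4cccc(Cl)c4)c3)C2)cc1OC1CCCC1`: in this assay compound 3 gives only a limit, > 10000 nM.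

Compound 3 therefore stands at the limit of the assay, as do the other two measured compounds (the limit of > 10000 nM in this assay, at which 3 of the 3 values shown sit). Among the compounds with values here, none of the measured steps can be read: a step that the two limits leave unreadable from compound 1 to compound 2, a step that the two limits leave unreadable from compound 1 to compound 3 and a step that the two limits leave unreadable from compound 2 to compound 3 all run from one limit to another. Compound 4 `COc1ccc([C@H]2CC(=O)N(c3cccc(NS(=O)(=O)c4cc(Br)c(Cl)s4)c3)C2)cc1OC1CCCC1` differs from compound 3 by 4-bromo-5-chlorothiophen-2-yl in place of 3-chlorophenyl on a sulfonyl sulfur. Within the data shown here, the measured step that comes closest to this change is the one from compound 2 to compound 3, which also exchanges the group on a sulfonyl sulfur, and it was unreadable. No step beyond the scatter is therefore expected in this assay. Compound 4 is expected to give 10000 nM, within 5000 nM to 30000 nM. The step expected from this is a number no higher from compound 3 to compound 4 (the limit leaves the size open).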

Compound 4, half-maximal cytotoxic concentration: > 10000 nM
Compound 4 ended at the assay's limit (the forecaster's own chance of this, stated with the estimate: 85%); the middle value sits exactly at the limit.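

The steps from compound 4 to compound 1, compound 2 and compound 3 cannot be read, as all four compounds sit at one limit: the limit of > 10000 nM in this assay, at which 4 of the 4 values shown sit. Left open is whether these four compounds differ at all in this assay.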